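Fluorine on the Fused Ring of Compound 2

A few compounds are considered here, and "the series" means these few. Any claim that something is new, unique, unknown or untested is made for them only; others in the source may bear on it.

Of the compounds shown here, two have been measured so far. Compound 1, with the structure `NC1=NCC(CC2=Cc3c(Cl)cccc3CC2)O1`, gives in a functional assay for binding affinity to Norepinephrine transporter (Rattus norvegicus), read by radioligand binding, in the presence of a further agent that is not named here (a lower number here means a stronger inhibitor, a higher number a weaker inhibitor), only a limit, < 1000 nM, rather than a number. Compound 2, with the structure `C1=NCC(Cc2cc3ccccc3o2)N1`, gives in this assay a true value of 63.1 nM. Among the compounds with values here, compound 2 thus stands as the only compound with a number, since the other entry is a limit, as the limit of < 1000 nM in this assay, at which 1 of the 2 values shown sits, records.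

The next compound follows from compound 2 by a single change. Compound 3, with the structure `Fc1ccc2oc(CC3CN=CN3)cc2c1`, differs from compound 2 by fluoro in place of hydrogen on an aromatic carbon. Within the data shown here, this is a small change, a single fluorine in place of a hydrogen on the six-membered ring of the fused system, and there is no measured step of this kind among the compounds above to lean on.

The expectation is therefore that compound 3 stays close to compound 2, with a step of a 1.3-fold lower number from compound 2 to compound 3 (0.10 log units; within the scatter) that does not go beyond the usual scatter. The value expected for compound 3 in this assay is 50 nM, with a range from 18 nM to 160 nM.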

Compound 3, inhibition constant: 794 nM
The estimate for compound 3 lay 16-fold (1.20 log units) below the measured number, and the stated range ends below it.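

Putting fluoro in place of hydrogen at this one position, meta to a fused ring and para to a fused ring, gives a 13-fold higher number from compound 2 to compound 3 (1.10 log units; beyond the scatter) in this assay, so compound 3 is a clearly weaker inhibitor than compound 2, and this position is far from indifferent to what it carries. Within the data shown here, no step between two measured compounds had been available before, and this first one shows that replacing a single hydrogen on this six-membered ring can move the number well beyond the usual scatter. What the compounds shown here offer does not explain the size of this step.

Only one replacement at one position is shown, so it remains open whether this loss is particular to fluoro or would also appear with a methyl group, a methoxy group or an amine in the same place. Going by these compounds, it also remains open whether fluoro on another carbon of the six-membered ring would give a step of similar size, or whether the weakening is confined to this one position.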